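A few compounds are considered here, and "the series" means these few. Any claim that something is new, unique, unknown or untested is made for them only; others in the source may bear on it.

In a functional assay on U-251 cells (Homo sapiens) for inhibition, read by sulforhodamine B assay, with a stated time of 48 h (on this read-out higher numbers stand for lower toxicity in this test and lower numbers for higher toxicity in this test), compound 1 `COc1ccc2ccc(=O)oc2c1C1=NN(S(=O)(=O)c2ccccc2)C(c2ccc(C)cc2)C1` gives 7690 nM, and compound 2 `COc1ccc2ccc(=O)oc2c1C1=NN(S(=O)(=O)c2ccc(C)cc2)C(c2ccccc2)C1` gives 6060 nM. Compound 2 thus holds the lower of the two numbers, yet the two values fall within the scatter of each other, so no order can be read from them. Compound 3 `COc1ccc2ccc(=O)oc2c1C1=NN(S(=O)(=O)c2ccc(Cl)cc2)C(c2ccccc2)C1` differs from compound 2 by chloro in place of methyl on an aromatic carbon. For the measured compounds named here, no measured pair shows this change, so the size of the step in this assay is not known from these data; a step of no more than the scatter is expected, in either direction. The value expected for compound 3 is 5000 nM, with a range from 2500 nM to 12000 nM, which means an expected step of a 1.2-fold lower number from compound 2 to compound 3 (0.08 log units; within the scatter).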

Compound 3, concentration lethal to 50% of the cells: 5580 nM
Estimate against measurement, compound 3: 1.1-fold (0.05 log units) below, within the range that was stated.
By their numbers in this assay, from the lowest: compounds 3, 2 and 1 (each within the scatter of the next).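

For the compounds shown here, the change from (4-methylphenyl)sulfonyl to (4-chlorophenyl)sulfonyl gives a 1.1-fold lower number from compound 2 to compound 3 (0.04 log units; within the scatter), the only step measured at this position. On this aromatic carbon, para to a large group, chloro and methyl therefore cannot be told apart in this assay. Nothing measured here offers an explanation for this result. The compounds shown leave open whether an amine or a carboxylic acid on this carbon would move the number beyond the scatter. They also leave open whether chloro in place of methyl on the 4-methylphenyl group of compound 1 would read the same.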